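Swapping the Benzyl Substituent: What to Expect for Compound 4

The source may report more compounds than this note shows. Statements on the series, on what has been measured and on what is new or still open speak of the compounds shown alone.

Measured so far in a functional assay on HCT-116 cells (Homo sapiens) for inhibition, read by MTT assay, with a stated time of 72 h; a higher number here means a weaker inhibitor of growth, a lower number a stronger inhibitor of growth:
compound 1 `N#Cc1ccc(Cn2cc(C[C@H](O)COCCOC[C@@H](O)Cc3ccc(-c4ccccc4)cc3)nn2)cc1`, 8800 nM
compound 2 `O[C@H](COCCOC[C@@H](O)Cc1cn(-c2ccc3c(c2)OCCO3)nn1)Cc1ccc(-c2ccccc2)cc1`, 16500 nM
compound 3 `O[C@H](COCCOC[C@@H](O)Cc1cn(Cc2ccc(C(F)(F)F)cc2)nn1)Cc1ccc(-c2ccccc2)cc1`, 2500 nM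

Compound 1 stands second highest of the three numbers: compound 2 lies close, a 1.9-fold higher number from compound 1 to compound 2 (0.27 log units; within the scatter), while compound 3 lies clearly apart, a 3.5-fold lower number from compound 1 to compound 3 (0.55 log units; beyond the scatter). Compound 4 `O[C@H](COCCOC[C@@H](O)Cc1cn(Cc2ccc3ccccc3c2)nn1)Cc1ccc(-c2ccccc2)cc1` differs from compound 1 in one place: naphthalen-2-yl in place of 4-cyanophenyl on a saturated chain carbon bound to an aromatic nitrogen. Among the compounds with values here, two measured steps bear on this change. The nearest is a 3.5-fold lower number from compound 1 to compound 3 (0.55 log units; beyond the scatter), where the cyano on an aromatic carbon was exchanged for another group; the step of a 6.6-fold lower number from compound 2 to compound 3 (0.82 log units; beyond the scatter) adds that a benzyl-type group on the aromatic nitrogen gave a lower number than a directly attached aryl. A modest downward step is therefore expected for compound 4, a 2.8-fold lower number from compound 1 to compound 4 (0.44 log units; beyond the scatter). The estimate for compound 4 is 3200 nM, within 1200 nM to 8500 nM.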

Compound 4, concentration for 50% growth inhibition: 8600 nM
Compound 4: middle estimate off by 2.7-fold (0.43 log units), on the low side; measured number above the stated range.
By their numbers in this assay, from the lowest: compound 3; then compounds 4, 1 and 2 (each within the scatter of the next).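

In this assay, naphthalen-2-yl in this place does not reproduce the gain seen with 4-(trifluoromethyl)phenyl (a 3.4-fold higher number from compound 3 to compound 4 (0.54 log units; beyond the scatter)) and stays level with 4-cyanophenyl (a 1.0-fold lower number from compound 1 to compound 4 (0.01 log units; within the scatter)). A (naphthalen-2-yl)methyl group on the aromatic nitrogen also stays level with a directly attached 2,3-dihydro-1,4-benzodioxin-6-yl (a 1.9-fold lower number from compound 2 to compound 4 (0.28 log units; within the scatter)), so a benzyl-type group does not by itself give a lower number. Nothing measured here explains why compound 3 stands apart.

From the compounds shown here alone, whether plain benzyl or 4-chlorobenzyl would stand with compound 3 or with compound 1 remains open.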